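Methoxy for methyl on the amide nitrogen aryl group

This account rests on a few compounds, and the source may have more. Where it says the series, first, only, none or still open, it means among the compounds named here.

Measured compounds:
Compound 1, `O=C1COc2ccc(-c3cccc(NS(=O)(=O)c4ccc(F)cc4)c3)cc2N1C1CC1`, gives in a functional assay on MCF7 cells (Homo sapiens) for antiproliferative activity, read by MTT assay, with a stated time of 72 h (on this read-out higher numbers stand for weaker inhibition and lower numbers for stronger inhibition), a value of > 40000 nM, which is a limit of the assay.
Compound 2, `Cc1ccc(N2C(=O)COc3ccc(-c4cnc5ccccc5c4)cc32)cc1`, gives in this assay a value of > 40000 nM, again a limit of the assay.
Compound 3, `O=C1COc2ccc(-c3cnc(Cl)c(NS(=O)(=O)c4ccc(F)cc4)c3)cc2N1C1CCCCC1`, gives in this assay a value of > 40000 nM, also a limit of the assay.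

Compound 2 therefore stands at the limit, where every measured value of this set sits, as the limit of > 40000 nM in this assay, at which 3 of the 3 values shown sit, records. Among the measured compounds shown here, none of the three measured compounds gives a number, so no measured step between them exists, and nothing in the data separates one from another.

Compound 4, `COc1cccc(N2C(=O)COc3ccc(-c4cnc5ccccc5c4)cc32)c1`, has not yet been measured in this assay. It differs from compound 2 in one place: 3-methoxyphenyl in place of 4-methylphenyl on an amide-type nitrogen in a ring.

For the measured compounds named here, since the only values shown are limits, the step from compound 2 to compound 4 is expected to be none beyond the scatter, and compound 4 is expected to remain at or near the limit, a step that the limit leaves unreadable from compound 2 to compound 4. Compound 4 is estimated in this assay at 50000 nM, with a range from 15000 nM to 200000 nM.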

Compound 4, half-maximal inhibitory concentration: > 40000 nM
Compound 4: a limit, no number; the forecaster's own chance of this, stated with the estimate: 80%; the middle value lies beyond the limit too.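

In this assay compound 4 gives > 40000 nM, which is a limit of the assay. With compound 2 also at a limit, the step between compound 2 and compound 4 cannot be read. The compounds shown leave open which group on the shared core, if any, would give a measurable number.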